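The compounds below may be only part of what the source reports. "The series", "measured", "known", "first", "only" and "open" are said of these compounds alone.

Of the compounds shown here, three have been tested in a functional assay on EA.hy 926 cells (Homo sapiens) for cytotoxicity, read by MTT assay, with stated times of 24 h and 12 h, tested at 50 uM (a higher number here means a stronger effect of the compound at the concentration tested, a lower number a weaker effect), and a fourth is still to be measured. Compound 1, with the structure `COc1cc(/C=C/C(=O)O)cc(OC)c1OC(=O)c1nc(C)c(C)nc1C`, gives 96.6%. Compound 2, with the structure `CCOC(=O)/C=C/c1cc(OC)c(OC(=O)c2nc(C)c(C)nc2C)c(OC)c1`, gives -13.6%. These two differ in one place only: ethyl in place of hydrogen on an oxygen next to a carbonyl group. This single change produced a number 110.2 percentage points lower from compound 1 to compound 2 (beyond the scatter), a large fall that lies well beyond the usual scatter of repeated measurements.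

Compound 3, with the structure `Cc1nc(C)c(C(=O)Oc2cccc(/C=C/C(=O)O)c2)nc1C`, gives 75.3% in this assay. It stands second highest of the three measured numbers. Its core is built differently from that of compound 1, and the difference between the two cores is not broken down here.

The unmeasured compound 4 has the structure `CCOC(=O)/C=C/c1cccc(OC(=O)c2nc(C)c(C)nc2C)c1`. It is related to compound 3 by ethyl in place of hydrogen on an oxygen next to a carbonyl group, which is the same change that turned compound 1 into compound 2, down to the surroundings of the place where it occurs. If this change acts on the core of compound 3 as it acted on the core of compound 1, a drop of a similar size should follow. Compound 4 is therefore expected to give about -10% in this assay, somewhere between -45% and 30%. That implies an expected step of a number 85.3 percentage points lower from compound 3 to compound 4 (beyond the scatter), because the identical change already produced a number 110.2 percentage points lower from compound 1 to compound 2 (beyond the scatter).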

Compound 4, a percentage reported as activity, at one concentration (the size of the read-out at that concentration, not a potency): 39.5%
Beside the measured number, compound 4's estimate is 49.5 percentage points below it; measured number above the stated range.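

Putting ethyl in place of hydrogen on an oxygen next to a carbonyl group, which turns the carboxy group into an ethoxycarbonyl group, again lowers the read-out in this assay, this time with a number 35.8 percentage points lower from compound 3 to compound 4 (beyond the scatter). The direction of the change therefore carries over from one core to the other, but its size does not, so a step measured on one core is a poor guide to the exact size on the other: the same change on two cores in this assay, a number 110.2 percentage points lower (beyond the scatter) from compound 1 to compound 2 and a number 35.8 percentage points lower (beyond the scatter) from compound 3 to compound 4, 74.4 percentage points apart, beyond the scatter of two such steps. For the compounds shown here, with only two cores, this shows that the core matters to the size of the step, but it does not show which part of the core is responsible, why the size differs, or whether the same direction would hold on a third core.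

The compounds shown leave open how a methyl ester, a longer chain on that oxygen, or an amide in place of the ester would behave on either core, and so whether the fall belongs to ethyl in particular or to any replacement of that hydrogen. Going by these compounds, each number is also a read-out at one concentration and not a potency, so how these steps would look across a range of concentrations remains open.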